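A few compounds are considered here, and "the series" means these few. Any claim that something is new, unique, unknown or untested is made for them only; others in the source may bear on it.

Measured compounds:

compound 1 `COC(=O)CC(=O)N1N=C(c2ccc(N3CCN(C)CC3)cc2)CC1c1ccc(N(C)C)cc1` — in a functional assay on NCI-H1975 cells (Homo sapiens) for inhibition, read by sulforhodamine B assay, tested at 10 uM (on this read-out higher numbers stand for more inhibition at the one concentration tested (going by the name of the read-out) and lower numbers for less inhibition), compound 1 gives -2.2%
compound 2 `COC(=O)CC(=O)N1N=C(c2ccc(-n3cncn3)cc2)CC1c1ccc(N(C)C)cc1` — in this assay compound 2 gives 1.5%

Within the data shown here, both numbers sit close to zero, and the one step between them, a number 3.7 percentage points higher from compound 1 to compound 2 (within the scatter), lies within the scatter; compound 2 therefore cannot be set apart from compound 1 on these readings, and neither compound shows inhibition beyond the noise of this read-out.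

The next compound, compound 3 `CN(C)c1ccc(C2CC(c3ccc(-n4cncn4)cc3)=NN2C(=O)c2ccc(C(F)(F)F)cc2)cc1`, differs from compound 2 in one place: 4-(trifluoromethyl)phenyl in place of (methoxycarbonyl)methyl on a carbonyl carbon. Among the measured compounds shown here, no measured step bears on this position, since the only step so far concerns the substituent on the aromatic carbon, with the carbonyl side chain held the same in compound 1 and compound 2. For the measured compounds named here, there is thus no precedent for how a change at the carbonyl carbon moves the read-out, and the expectation for compound 3 rests only on the two measured values, which both lie at the level of no inhibition.

The step from compound 2 to compound 3 is expected to be a number 3.5 percentage points higher from compound 2 to compound 3 (within the scatter), with no direction supported beyond the scatter. On these data alone, compound 3 is estimated at 5%, in a range from -10% to 25%; the range is wide, as the change at the carbonyl carbon is untested.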

Compound 3, a percentage reported as inhibition, at one concentration (the size of the read-out at that concentration, not a potency): 11.5%
Beside the measured number, compound 3's estimate is 6.5 percentage points below it; the measured number falls inside the stated range.
By their numbers in this assay, from the lowest: compounds 1, 2 and 3 (each within the scatter of the next, the first and the last beyond it).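

Working notes on the carbonyl position: this is the first reading at this position, and 4-(trifluoromethyl)phenyl in place of (methoxycarbonyl)methyl on the carbonyl carbon gives a number 10 percentage points higher from compound 2 to compound 3 (within the scatter) in this assay. The position therefore accepts a six-membered aromatic ring of carbon only instead of a chain with no ring, and the loss of the ester's two hydrogen-bond acceptors leaves a reading that cannot be set apart from that of compound 2, although the step lies at the edge of what the scatter allows. Nothing measured on these compounds accounts for the step or says which part of the new group would matter.

The compounds shown leave open whether the step at the carbonyl carbon reflects a true change or only scatter, and whether it would hold with 4-methylpiperazin-1-yl on the aromatic carbon in place of the 1H-1,2,4-triazol-1-yl of compound 3. They also leave open how the read-out would respond on the carbonyl carbon to an unsubstituted phenyl, to a carboxylic acid at the end of the chain, or to a longer chain ending in an amine.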